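Chloro for hydrogen on the acetamido of compound 2

The compounds below may be only part of what the source reports. "The series", "measured", "known", "first", "only" and "open" are said of these compounds alone.

Three sulfonate esters built on one shared core have been measured in a functional assay on HT-1080 cells (Homo sapiens) for antiproliferative activity, read by sulforhodamine B assay, with a stated time of 48 h; a higher number here means a weaker inhibitor, a lower number a stronger inhibitor. Compound 1 `CC(C)C(=O)Nc1cccc(S(=O)(=O)Oc2ccccc2C(C)C)c1` gives 16000 nM, compound 2 `CC(=O)Nc1ccc(S(=O)(=O)Oc2ccccc2C(C)C)cc1` gives 12000 nM, and compound 3 `CC(=O)Nc1ccc(S(=O)(=O)Oc2ccccc2I)cc1` gives 17000 nM. Compound 2 therefore sits alongside the other two: its number lies within the scatter of compound 1 and of compound 3, so no order among the three can be read from this assay.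

The next compound, compound 4 `CC(C)c1ccccc1OS(=O)(=O)c1ccc(NC(=O)CCl)cc1`, differs from compound 2 by chloro in place of hydrogen on a saturated chain carbon bound to a carbonyl carbon. Among the measured compounds shown here, the only single-place step on record, a 1.4-fold higher number from compound 2 to compound 3 (0.15 log units; within the scatter), concerns an aromatic substituent at the far end of the molecule and does not touch the acetamido, so it says little about the present change. Compound 1 differs from compound 2 in more than one place, and its value and that of compound 2 lie within the scatter of each other.

For the measured compounds named here, with no measured step bearing on chloro replacing hydrogen on the chain carbon bound to the carbonyl, the expectation for compound 4 is a number close to that of compound 2, a 1.3-fold lower number from compound 2 to compound 4 (0.12 log units; within the scatter), with no change beyond the scatter. Compound 4 is estimated at 9000 nM, in the range 3000 nM to 30000 nM.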

Compound 4, half-maximal inhibitory concentration: 1000 nM
The estimate for compound 4 lay 9.0-fold (0.95 log units) above the measured number; the measured number lies below the stated range.
By their numbers in this assay, from the lowest: compound 4; then compounds 2, 1 and 3 (each within the scatter of the next).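

Compound 4 shows that the acetamido of compound 2 is a place where a small change can matter in this assay: chloro in place of hydrogen on a saturated chain carbon bound to a carbonyl carbon gives a 12-fold lower number from compound 2 to compound 4 (1.08 log units; beyond the scatter), a large step from a single heavy atom. Among the compounds shown here, the only earlier single-place step, a 1.4-fold higher number from compound 2 to compound 3 (0.15 log units; within the scatter), concerned a different part of the molecule, an aromatic carbon, and gave no sign that the number could move this far on the shared core. No measurement among those given accounts for the size of this step.

The compounds shown leave open whether the step belongs to chloro itself or would also appear with fluoro, bromo, hydroxy or an amine on the same chain carbon, and whether a longer chain carrying chloro would keep it. They also leave open whether the same change would give a step of similar size with iodo in place of isopropyl on the aromatic carbon, as in compound 3.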